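The compounds below may be only part of what the source reports. "The series", "measured", "known", "first", "only" and "open" are said of these compounds alone.

Compound 1 `CN1C/C(=C\c2ccccc2)C(=O)[C@]2(C1)[C@@H](c1ccccc1)CN(C)[C@@]21C(=O)Nc2ccccc21` gives 77% in a functional assay on the whole organism (strain Wister albino) for inhibition, with Rattus norvegicus as the target, read by paw edema, with a stated time of 1 h, at a dose of 50 mg/kg by the intraperitoneal route (on this read-out lower numbers stand for less inhibition and higher numbers for more inhibition at the one dose given (going by the name of the read-out)), and compound 2 `CN1C/C(=C\c2ccccc2)C(=O)[C@]2(C1)[C@@H](c1ccccc1)CN(C)[C@@]21C(=O)N(C)c2ccccc21` gives 68% in the same assay. Compound 3 `CN1C/C(=C\c2ccc(Br)cc2)C(=O)[C@]2(C1)[C@@H](c1ccc(Br)cc1)CN(C)[C@@]21C(=O)Nc2ccccc21` gives 77.7% in this assay; its number lies within the usual scatter of both compound 1 and compound 2, so no order among the three can be read from these figures. Compound 4 `CN1C/C(=C\c2ccc(Br)cc2)C(=O)[C@]2(C1)[C@@H](c1ccc(Br)cc1)CN(C)[C@@]21C(=O)N(C)c2ccccc21` differs from compound 3 by methyl in place of hydrogen on an amide-type nitrogen in a ring. Going by the values given here, the single measured step of this kind, a number 9 percentage points lower from compound 1 to compound 2 (within the scatter), bears on it directly. Because a number 9 percentage points lower from compound 1 to compound 2 (within the scatter) stayed within the scatter, compound 4 is expected to show a step of about a number 6.7 percentage points lower from compound 3 to compound 4 (within the scatter) in this assay, a shift not beyond the scatter. Compound 4 is therefore estimated at 71%, with a range from 58% to 81%.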

Compound 4, a percentage reported as inhibition, in the whole organism at one dose (the size of the read-out at that dose, not a potency): 53.5%
Beside the measured number, compound 4's estimate is 17.5 percentage points above it; the whole stated range lies above it.
By their numbers in this assay, from the lowest: compound 4; then compounds 2, 1 and 3 (each within the scatter of the next).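

In this assay, methyl in place of hydrogen on an amide-type nitrogen in a ring now gives a result beyond the scatter, a number 24.2 percentage points lower from compound 3 to compound 4 (beyond the scatter), so the amide hydrogen can count at this position. The size of the step depends on the core that carries it: the same change on two cores in this assay, a number 9 percentage points lower (within the scatter) from compound 1 to compound 2 and a number 24.2 percentage points lower (beyond the scatter) from compound 3 to compound 4, 15.2 percentage points apart, beyond the scatter of two such steps.

The compounds shown leave open whether an ethyl group, a longer chain or a chain ending in a carboxylic acid on this nitrogen would lower the number further or restore it. They also do not tell what sets the size of the step on each core.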